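Fluorophenyl for hydroxyphenyl on the shared core

The compounds below may be only part of what the source reports. "The series", "measured", "known", "first", "only" and "open" are said of these compounds alone.

compound 1 `COc1ccc(S(=O)(=O)N2CCc3cccc(-c4ccc(O)cc4)c32)cc1` 133 nM
compound 2 `COc1ccc(S(=O)(=O)N2CCc3cccc(-c4c(F)c(F)c(F)c(F)c4F)c32)cc1` 3900 nM
compound 3 `COc1ccc(S(=O)(=O)n2ccc3cccc(-c4ccc(F)cc4)c32)cc1` 196 nM

In a functional assay on HT-29 cells (Homo sapiens) for inhibition, with a stated time of 72 h (a higher number here means a weaker inhibitor, a lower number a stronger inhibitor), compound 1 gives the lowest of the three numbers; compound 3 sits within the scatter of it, while compound 2 stands well beyond the scatter with the weakest inhibition seen. For the measured compounds named here, no pair of measured compounds differs in one place, so no single step is established. Compound 4 `COc1ccc(S(=O)(=O)N2CCc3cccc(-c4cccc(F)c4)c32)cc1` differs from compound 1 as follows: 3-fluorophenyl in place of 4-hydroxyphenyl on an aromatic carbon. Compound 3 likewise has no hydrogen-bond donor and gives 196 nM, within the scatter of compound 1, so the loss of the donor alone does not look costly. The step of a 1.9-fold higher number from compound 1 to compound 4 (0.27 log units; within the scatter) is expected to be small, at most a slight rise in the number. Compound 4 is estimated at 250 nM, range 90 nM to 700 nM.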

Compound 4, half-maximal inhibitory concentration: 119 nM
For compound 4 the middle estimate is 2.1-fold (0.32 log units) above the measured one; the measured number falls inside the stated range.
By their numbers in this assay, from the lowest: compounds 4, 1 and 3 (each within the scatter of the next); then compound 2.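

In this assay, 3-fluorophenyl in place of 4-hydroxyphenyl on an aromatic carbon gives a 1.1-fold lower number from compound 1 to compound 4 (0.05 log units; within the scatter). For the compounds shown here, on the shared core, this position therefore takes a phenyl group with 0 hydrogen-bond donors without a change that can be read, and this is the first single step. Nothing available gives a reason for this outcome.

The step changes both the substituent and its place on the phenyl ring, so the two cannot be separated. Going by these compounds, how an amine or a carboxylic acid on that phenyl ring would read remains open.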